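From nitro to 2,4-difluorophenyl on the shared core

A few compounds are considered here, and "the series" means these few. Any claim that something is new, unique, unknown or untested is made for them only; others in the source may bear on it.

compound 1 `COc1ccc(Cl)cc1C(=O)Nc1ccc([N+](=O)[O-])cc1Cl` gives 1010 10^-6 cm/s
compound 2 `Cc1ccc(O)c(C(=O)Nc2ccc([N+](=O)[O-])cc2Cl)c1` gives 134 10^-6 cm/s
compound 3 `O=C(Nc1ccc([N+](=O)[O-])cc1Cl)c1cc([N+](=O)[O-])ccc1O` gives 30.3 10^-6 cm/s

In an ADME assay for permeability, using PAMPA (a lower number here means that the compound crosses the layer more slowly, a higher number that the compound crosses the layer faster), compound 3 stands at 30.3 10^-6 cm/s and is the lowest of the three measured compounds, with compound 2 nearest and compound 1 far higher at 1010 10^-6 cm/s on the same scale. Among the measured compounds shown here, the one measured step that bears on what follows, with nitro in place of methyl on an aromatic carbon, is a 4.4-fold lower number from compound 2 to compound 3 (0.65 log units; beyond the scatter) and counts as modest.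

In compound 4 `O=C(Nc1ccc([N+](=O)[O-])cc1Cl)c1cc(-c2ccc(F)cc2F)ccc1O` 2,4-difluorophenyl stands in place of nitro on an aromatic carbon, para to a hydroxy group (2,4-difluorophenyl in place of nitro on an aromatic carbon). For the measured compounds named here, no measured compound carries this group, so the data offer only a loose guide. With nitro leaving, compound 2 at 134 10^-6 cm/s is the closest reference, and a rise of similar size to the measured step is expected. The estimated change in this assay is a 4.0-fold higher number from compound 3 to compound 4 (0.60 log units; beyond the scatter) in this expectation. Compound 4 is estimated at 120 10^-6 cm/s with an expected range from 35 10^-6 cm/s to 420 10^-6 cm/s in this assay.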

Compound 4, apparent permeability: < 23.7 10^-6 cm/s
Compound 4 was reported as a limit; the forecaster's own chance of this, stated with the estimate: 3%; at least 5.0-fold (0.70 log units) between middle value and limit.
By their numbers in this assay, from the lowest: compound 3; then compound 2; then compound 1. At a limit, below all of these: compound 4.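

Compound 4 gives only a limit in this assay, not a number: the limit of < 23.7 10^-6 cm/s in this assay, at which 1 of the 4 values shown sits. With 2,4-difluorophenyl in place of methyl on this aromatic carbon, para to a hydroxy group, the reading is an at least 5.6-fold lower number from compound 2 to compound 4 (0.75 log units; beyond the scatter), so a group counted with no hydrogen-bond acceptors also sits well under the methyl compound, which the nitro step alone could not show. With the same group in place of nitro, the reading is an at least 1.2-fold lower number from compound 3 to compound 4 (0.10 log units; that floor lies within the scatter), and because that floor lies within the scatter, compound 4 is clearly separated from compound 2 but not from compound 3.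

From the compounds shown here alone, how far compound 4 lies under its limit stays open. So does where a plain phenyl or an amine on this carbon would fall relative to methyl and nitro.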